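Trifluorophenyl step from compound 3 to compound 4

This account rests on a few compounds, and the source may have more. Where it says the series, first, only, none or still open, it means among the compounds named here.

Values in a functional assay on HL-60 cells (Homo sapiens) for antiproliferative activity, with a stated time of 72 h (a higher number here means a weaker inhibitor, a lower number a stronger inhibitor), so far:
- compound 1 `Cc1ccc(CNc2ncnc3c2ncn3[C@@H]2O[C@H](CO)[C@@H](O)[C@H]2O)cc1` gives > 166000 nM (a limit)
- compound 2 `COc1cccc(CNc2ncnc3c2ncn3[C@@H]2O[C@H](CO)[C@@H](O)[C@H]2O)c1` gives 4900 nM
- compound 3 `COc1cccc(CNc2ncnc3c2ncn3[C@@H]2O[C@H](CO)[C@@H](O)[C@H]2O)c1OC` gives > 166000 nM (a limit)

Compound 3 has only a limit in this assay and no number; this is the limit of > 166000 nM in this assay, at which 2 of the 3 values shown sit, in the series. Compound 4 `OC[C@H]1O[C@@H](n2cnc3c(NCc4c(F)ccc(F)c4F)ncnc32)[C@H](O)[C@@H]1O` is still unmeasured. The change is 2,3,6-trifluorophenyl in place of 2,3-dimethoxyphenyl on a saturated chain carbon bound to a nitrogen on an aromatic ring, with 2,3,6-trifluorophenyl in place of 2,3-dimethoxyphenyl on a saturated chain carbon bound to a nitrogen on an aromatic ring.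

Two measured steps at this aryl group bear on it: an at least 33-fold lower number from compound 1 to compound 2 (1.52 log units; beyond the scatter) and an at least 33-fold higher number from compound 2 to compound 3 (1.52 log units; beyond the scatter). Both are large, so changes here can move the read-out sharply, though neither step involves fluorine. The third step, a step that the two limits leave unreadable from compound 1 to compound 3, adds nothing. With compound 3 at a limit, only a move to a lower number could be seen, and compound 4 may well stay at that limit. The expected step, which is highly uncertain, is an at least 5.5-fold lower number from compound 3 to compound 4 (0.74 log units; beyond the scatter) in that direction. For compound 4 the estimate is 30000 nM, with an expected range of 2500 nM to 166000 nM.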

Compound 4, half-maximal inhibitory concentration: 13000 nM
Compound 4: the middle estimate sits 2.3-fold (0.36 log units) above what was measured, and the stated range covers the measured number.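

In this assay, among the compounds shown here, the 2,3,6-trifluorophenyl group gives a measurable value at this saturated chain carbon without any methoxy group, a result that the earlier compounds did not show: an at least 12-fold lower number from compound 3 to compound 4 (1.10 log units; beyond the scatter), and an at least 12-fold lower number from compound 1 to compound 4 (1.10 log units; beyond the scatter). For the compounds shown here, the 3-methoxyphenyl group is therefore not the only aryl group here with a measurable value, although the comparison with it still gives a 2.7-fold higher number from compound 2 to compound 4 (0.42 log units; beyond the scatter). The first two steps give only minimum sizes, because compound 1 and compound 3 each stand at a limit rather than a number: the limit of > 166000 nM in this assay, at which 2 of the 4 values shown sit.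

With one fluorinated pattern shown, the compounds do not separate the contribution of each fluorine, and a monofluorophenyl or chlorophenyl group would test this. Going by these compounds, the effect of a longer chain in place of the benzylic carbon also remains open.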